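Biphenyl to phenyl on the ring nitrogen aryl group

The source may report more compounds than this note shows. Statements on the series, on what has been measured and on what is new or still open speak of the compounds shown alone.

Measured compounds:
- compound 1 `O=C(CC1c2ccccc2N=C(SCCCCCN2CCCC2)N1c1ccccc1)NCc1ccc(F)cc1`: 664000 nM
- compound 2 `O=C(CC1c2ccccc2N=C(SCCCCCN2CCCC2)N1c1ccc(-c2ccccc2)cc1)NCc1ccccc1`: 810 nM

In an assay on cells for inhibition of Voltage-dependent T-type calcium channel subunit alpha-1I (Homo sapiens), read by patch clamp (a lower number here means a stronger inhibitor, a higher number a weaker inhibitor), compound 2 gives 810 nM, the lowest of the two numbers. Compound 1 gives 664000 nM in this assay, a far higher number, and the gap between compound 2 and compound 1 lies well beyond the scatter.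

Compound 3 `O=C(CC1c2ccccc2N=C(SCCCCCN2CCCC2)N1c1ccccc1)NCc1ccccc1` has not yet been measured in this assay. It differs from compound 2 by hydrogen in place of phenyl on an aromatic carbon. Among the measured compounds shown here, no step between measured compounds covers this change. Compound 1, which also carries phenyl rather than 4-phenylphenyl on the shared core, sits at the weak end of the two numbers, so a large loss is expected: a step of a 120-fold higher number from compound 2 to compound 3 (2.09 log units; beyond the scatter), towards a much higher number, beyond the scatter. For compound 3 the expected value in this assay is 100000 nM, within a range of 8000 nM to 700000 nM.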

Compound 3, half-maximal inhibitory concentration: 6190 nM
Estimate against measurement, compound 3: 16-fold (1.21 log units) above; measured number outside the range, below it.
By their numbers in this assay, from the lowest: compound 2; then compound 3; then compound 1.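

In this assay, going from 4-phenylphenyl to phenyl on the shared core is a modest loss, a 7.6-fold higher number from compound 2 to compound 3 (0.88 log units; beyond the scatter), so compound 3 remains an inhibitor without the outer phenyl. The larger of the two new steps comes from removing the fluoro group, a 110-fold lower number from compound 1 to compound 3 (2.03 log units; beyond the scatter), which ties most of the weakness of compound 1 to the fluoro rather than to the phenyl. No measurement available here accounts for either step.

Going by these compounds, each step rests on a single pair, so it remains open whether chloro or methoxy on that aromatic carbon would bring the same large loss as fluoro. On these data alone, it is also open whether a methyl or a chloro in place of the outer phenyl would recover the gap between phenyl and 4-phenylphenyl.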